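Replacing 4-bromophenyl with 3-nitrophenyl on a shared core

The source may hold more compounds than are shown below. What is called first, only, known or untested is meant among the compounds shown, and "the series" means these compounds.

Of the compounds shown here, three built on one shared core have been measured in a functional assay on MCF7 cells (Homo sapiens) for cytotoxicity, read by MTT assay, with a stated time of 24 h; on this read-out higher numbers stand for weaker inhibition and lower numbers for stronger inhibition. Compound 1 (`C/C(=N\NC(=O)/C(C#N)=C/c1ccc(O)cc1)c1c(O)c2ccc(O)cc2oc1=O`) gives 7320 nM, compound 2 (`COc1ccc(/C=C(\C#N)C(=O)N/N=C(\C)c2c(O)c3ccc(O)cc3oc2=O)cc1`) gives 8940 nM, and compound 3 (`C/C(=N\NC(=O)/C(C#N)=C/c1ccc(Br)cc1)c1c(O)c2ccc(O)cc2oc1=O`) gives 9850 nM. Compound 3 thus stands together with the other two, and neither of its steps leaves the scatter: a 1.3-fold higher number from compound 1 to compound 3 (0.13 log units; within the scatter) and a 1.1-fold higher number from compound 2 to compound 3 (0.04 log units; within the scatter).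

Compound 4 (`C/C(=N\NC(=O)/C(C#N)=C/c1cccc([N+](=O)[O-])c1)c1c(O)c2ccc(O)cc2oc1=O`) has not yet been measured. It differs from compound 3 in one place: 3-nitrophenyl in place of 4-bromophenyl on a double-bonded chain carbon bound to a double-bonded chain carbon. In words, 3-nitrophenyl stands in place of 4-bromophenyl on a double-bonded chain carbon bound to a double-bonded chain carbon.

Among the compounds with values here, no measured compound carries 3-nitrophenyl, so the evidence for this change is indirect. It rests on the exchanges among hydroxy, methoxy and bromo on the aromatic ring. Besides the two steps already given, these include a 1.2-fold higher number from compound 1 to compound 2 (0.09 log units; within the scatter), and all three stayed within the scatter. Going by these compounds, on that basis, no step beyond the scatter is expected in this assay, although the new group is untested and the range must stay wide. The estimated step is a 1.1-fold lower number from compound 3 to compound 4 (0.06 log units; within the scatter). Compound 4 is estimated at 8600 nM, with an expected range from 4000 nM to 18000 nM.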

Compound 4, half-maximal inhibitory concentration: 16400 nM
The estimate for compound 4 lay 1.9-fold (0.28 log units) below the measured number, and the stated range covers the measured number.
By their numbers in this assay, from the lowest: compounds 1, 2, 3 and 4 (each within the scatter of the next, the first and the last beyond it).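

In this assay, 3-nitrophenyl in place of 4-bromophenyl gives a 1.7-fold higher number from compound 3 to compound 4 (0.22 log units; within the scatter), and 3-nitrophenyl in place of 4-methoxyphenyl gives a 1.8-fold higher number from compound 2 to compound 4 (0.26 log units; within the scatter), whereas 3-nitrophenyl in place of 4-hydroxyphenyl gives a 2.2-fold higher number from compound 1 to compound 4 (0.35 log units; beyond the scatter), the only step among these four compounds that leaves the scatter, and a modest one. Exchanges at this place on the double-bonded chain carbon can therefore move the number beyond the scatter, but here this holds only against compound 1, with compound 2 and compound 3 going against any general separation of compound 4 from the others. Nothing available here accounts for the step from compound 1 to compound 4 or says what underlies it.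

The compounds shown leave open whether this step belongs to the nitro group itself or to its place on the ring, a question that 4-nitrophenyl and 3-hydroxyphenyl would help to separate. Also open, going by these compounds, is how an unsubstituted phenyl, an aminophenyl or a carboxyphenyl would read at this place on the shared core.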